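Naphthalen-1-yl in Place of 4-Methoxyphenyl on the Ring Nitrogen

The source may report more compounds than this note shows. Statements on the series, on what has been measured and on what is new or still open speak of the compounds shown alone.

For the measured compounds named here, compound 3 `COc1ccc(N2CCN(Cc3csc(N)c3C(=O)c3ccc(Cl)cc3)CC2)cc1` gives 0% in a functional assay on CHO cells with adenosine receptor A1 (Homo sapiens) as the target, read by cAMP accumulation and immunoassay, with a stated time of 6 min, tested at 0.1 uM (on this read-out higher numbers stand for a weaker effect at the one concentration tested and lower numbers for a stronger effect), the second highest of the three numbers measured so far. Its nearest neighbour is compound 1 `CC(C)N1CCN(Cc2csc(N)c2C(=O)c2ccc(Cl)cc2)CC1`, which gives 3.6%, while compound 2 `Nc1scc(CN2CCN(c3ccc(Cl)cc3F)CC2)c1C(=O)c1ccc(Cl)cc1` gives -9.4%. Going by the values given here, the only step beyond the scatter is a number 13 percentage points lower from compound 1 to compound 2 (beyond the scatter); the step of a number 3.6 percentage points lower from compound 1 to compound 3 (within the scatter) stays within it. Compound 4 `Nc1scc(CN2CCN(c3cccc4ccccc34)CC2)c1C(=O)c1ccc(Cl)cc1` differs from compound 3 in one place: naphthalen-1-yl in place of 4-methoxyphenyl on an amine nitrogen in a ring. The step that bears most directly, an exchange of one aromatic group for another on the same nitrogen, is a number 9.4 percentage points higher from compound 2 to compound 3 (within the scatter), within the scatter. A step of about a number 1 percentage points lower from compound 3 to compound 4 (within the scatter) is therefore expected, none beyond the scatter. Compound 4 is estimated at -1%, in a range from -12% to 10%.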

Compound 4, a percentage reported as activity, at one concentration (the size of the read-out at that concentration, not a potency): 0%
Compound 4: middle estimate off by 1 percentage points, on the low side, and the stated range covers the measured number.
By their numbers in this assay, from the lowest: compounds 2, 3, 4 and 1 (each within the scatter of the next, the first and the last beyond it).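

In this assay, naphthalen-1-yl on the ring nitrogen gives no change at the digits printed from compound 3 to compound 4 (within the scatter) and so a second aromatic ring, with the hydrogen-bond acceptor gone, leaves the read-out where it was. The other two steps, a number 9.4 percentage points higher from compound 2 to compound 4 (within the scatter) and a number 3.6 percentage points lower from compound 1 to compound 4 (within the scatter) as well, also stay within the scatter, so this larger group does not set compound 4 apart from any compound shown. Nothing measured here explains this flat result.

As far as these compounds go, whether a carboxylic acid or a longer alkyl chain on this nitrogen would move the number remains open. So does the effect of these compounds at any other concentration, as the read-out gives only the size of the effect at the one concentration tested.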